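Trichloromethyl on the Core of Two Inactive Compounds

This account rests on a few compounds, and the source may have more. Where it says the series, first, only, none or still open, it means among the compounds named here.

Compound 1 `N#Cc1ccccc1-c1ccc(CSc2ncnc3ccccc23)cc1` was tested in an assay on isolated protein for inhibition of phosphodiesterase 7 (Homo sapiens), read by scintillation proximity assay and cAMP accumulation, with a stated time of 1 h; on this read-out lower numbers stand for stronger inhibition and higher numbers for weaker inhibition. In this assay compound 1 gives > 100000 nM, a limit of the assay rather than a number. Compound 2 `Cc1nc(SCc2ccc(-c3ccccc3C#N)cc2)c2ccccc2n1` gives > 100000 nM in this assay, again a limit. The step that the two limits leave unreadable from compound 1 to compound 2 is therefore unreadable, because both values sit at the limit of > 100000 nM in this assay, at which 2 of the 2 values shown sit. Compound 3 `N#Cc1ccccc1-c1ccc(CSc2nc(C(Cl)(Cl)Cl)nc3ccccc23)cc1` carries trichloromethyl in place of hydrogen on an aromatic carbon. For the measured compounds named here, the only measured step, a methyl in place of hydrogen on an aromatic carbon, offers no readable size, so the expected step that the limit leaves unreadable from compound 1 to compound 3 rests on no anchor. Compound 3 is expected near the limit, estimated at 150000 nM, within 20000 nM to 1000000 nM.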

Compound 3, half-maximal inhibitory concentration: > 100000 nM
Compound 3: only a limit was reported; the forecaster's own chance of this, stated with the estimate: 75%; the middle value lies beyond the limit too.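

For the compounds shown here, no step among compound 1, compound 2 and compound 3 can be read, as all three give only a limit: the limit of > 100000 nM in this assay, at which 3 of the 3 values shown sit. The compounds shown leave open how strongly each one inhibits, and whether methyl or trichloromethyl changes inhibition at all.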